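Swapping Methyl for Fluoro on the Shared Core

The compounds below may be only part of what the source reports. "The series", "measured", "known", "first", "only" and "open" are said of these compounds alone.

Compound 1 `Cc1cnc(Nc2ccc(C(=O)Nc3c(C)cccc3C)cc2)nc1-c1ccc(OC(F)(F)F)cc1` gives 1.3 nM in an assay on NIH3T3 cells for inhibition of Sonic hedgehog protein (Mus musculus), read by a luciferase reporter, with a stated time of 48 h; a lower number here means a stronger inhibitor, a higher number a weaker inhibitor.
Compound 2 `Cc1cnc(Nc2ccc(C(=O)Nc3c(C)cccc3C)cc2)nc1-c1cccc(OC(F)(F)F)c1` gives 1.2 nM in this assay.
Compound 3 `Cc1cnc(Nc2ccc(C(=O)Nc3c(C)cccc3C)cc2)nc1-c1ccccc1` gives 1.3 nM in this assay.

Compound 1 stands level with compound 3 at the digits printed, the two together giving the highest numbers of the three, and its gap to compound 2 is a 1.1-fold lower number from compound 1 to compound 2 (0.03 log units; within the scatter), which is within the scatter. Moving from compound 1 to compound 3 gives no change at the digits printed from compound 1 to compound 3 (within the scatter), and from compound 2 to compound 3 gives a 1.1-fold higher number from compound 2 to compound 3 (0.03 log units; within the scatter); all three measured steps change only the trifluoromethoxy group on the outer phenyl ring and none moves the number beyond the scatter.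

Compound 4 `Cc1cccc(C)c1NC(=O)c1ccc(Nc2ncc(F)c(-c3ccc(OC(F)(F)F)cc3)n2)cc1` differs from compound 1 in another place: fluoro in place of methyl on an aromatic carbon. For the measured compounds named here, no measured step touches this position on the shared core, so the three steps give no direct guide; they show only that the series so far sits at one level in this assay. With nothing pointing either way, the expected step from compound 1 to compound 4 is a 1.2-fold higher number from compound 1 to compound 4 (0.06 log units; within the scatter), none beyond the scatter, with a wider range to allow for the untested position. Compound 4 is therefore estimated at 1.5 nM, between 0.4 nM and 6 nM.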

Compound 4, half-maximal inhibitory concentration: 1.6 nM
The estimate for compound 4 lay 1.1-fold (0.03 log units) below the measured number, within the range that was stated.
By their numbers in this assay, from the lowest: compounds 2, 1, 3 and 4 (each within the scatter of the next).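

Measured in this assay the change from methyl to fluoro on the shared core gives a step (a 1.2-fold higher number from compound 1 to compound 4 (0.09 log units; within the scatter)) that stays within the scatter. For the compounds shown here, the earlier steps all lay on the outer phenyl ring, so this is the first reading at the carbon ortho to the 4-(trifluoromethoxy)phenyl group, and in this one pair either group leaves the number at the same level. Nothing available here explains this result or tells what the swap does at this position.

The compounds shown leave open whether an amine, a nitrile or a longer chain such as propyl on this carbon would stay at this level. They also leave open whether fluoro reads the same with the 3-(trifluoromethoxy)phenyl group or the plain phenyl ring.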